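This account rests on a few compounds, and the source may have more. Where it says the series, first, only, none or still open, it means among the compounds named here.

Three compounds sharing one core have gone through a physicochemical assay for acid dissociation, read by spectrophotometry, at 25 degrees C. Compound 1 `COC[C@]12C[C@H]1[C@@](C)(c1cc(NC(=O)c3ccc(Cl)cn3)cc(F)c1F)N=C(N)S2` gives 7.5 and compound 3 `CNC(=O)[C@]12C[C@H]1[C@@](C)(c1cc(NC(=O)c3ccc(Cl)cn3)cc(F)c1F)N=C(N)S2` gives 6.7. For compound 2 `C[C@]1(c2cc(NC(=O)c3ccc(Cl)cn3)cc(F)c2F)N=C(N)S[C@@]2(C(N)=O)C[C@H]21` the entry reads "not determined" (no result reported) and offers no number to compare. Going by the values given here, compound 3 therefore has the lower of only two available numbers.

The next compound is compound 4 `C[C@]1(c2cc(NC(=O)c3ccc(Cl)cn3)cc(F)c2F)N=C(N)S[C@@]2(C#N)C[C@H]21`, which has cyano in place of methylcarbamoyl on a saturated ring carbon. Among the compounds with values here, the only measured step at this carbon is a number 0.80 log units lower from compound 1 to compound 3 (beyond the scatter), with methylcarbamoyl in place of methoxymethyl. Within the data shown here, it shows that a change of group here can move the number beyond the scatter, but no compound carrying cyano has yet been measured. Among the measured compounds shown here, with a number 0.80 log units lower from compound 1 to compound 3 (beyond the scatter) as the only guide, the expected result in this assay is a further fall of similar size, estimated as a number 0.90 log units lower from compound 3 to compound 4 (beyond the scatter). For compound 4 the estimated value is 5.8, with an expected range from 5.2 to 6.4.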

Compound 4, acid dissociation constant: 6.2
The estimate for compound 4 lay 0.40 log units below the measured number, within the range that was stated.
By their numbers in this assay, from the lowest: compound 4; then compound 3; then compound 1.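

In this assay, the saturated ring carbon now carries three groups with numbers, and a second kind of change there also moves the result beyond the scatter: cyano in place of methylcarbamoyl gives a number 0.50 log units lower from compound 3 to compound 4 (beyond the scatter) and cyano in place of methoxymethyl gives a number 1.30 log units lower from compound 1 to compound 4 (beyond the scatter), the largest step among these compounds. Going by these compounds alone, the three groups therefore fall into an order, with cyano lowest, methylcarbamoyl in the middle and methoxymethyl highest, and no compound with a number goes against it. Nothing available explains why the groups fall in this order.

On these data alone, whether a plain methyl, an amine or a carboxylic acid on this carbon would land inside this spread or outside it stays open. So does whether the same order would hold if the shared core were changed elsewhere.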